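Chloro-to-fluoro swap on the sulfanyl phenyl ring

The source may hold more compounds than are shown below. What is called first, only, known or untested is meant among the compounds shown, and "the series" means these compounds.

Measured compounds:
- compound 1, `CC(O)(CSc1ccc(Cl)cc1)c1nc(-c2ccc(F)c(Cl)c2)no1`: 10000 nM
- compound 2, `CC(O)(CSc1ccc(F)cc1)c1nc(-c2ccc([N+](=O)[O-])c(C(F)(F)F)c2)no1`: 5500 nM

In a functional assay on PC-3 cells (Homo sapiens) for cytotoxicity, read by MTT assay (on this read-out higher numbers stand for weaker inhibition and lower numbers for stronger inhibition), compound 1 gives 10000 nM, the highest of the two numbers. Within the data shown here, compound 2, the only other measured compound, gives 5500 nM in this assay; the gap between the two lies within the scatter, so the pair shows no order. Among the measured compounds shown here, compound 2 carries the (4-fluorophenyl)sulfanyl group but a different aryl on the shared core, so no single step toward compound 3 is available.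

Compound 3, `CC(O)(CSc1ccc(F)cc1)c1nc(-c2ccc(F)c(Cl)c2)no1`, arises from compound 1 by fluoro in place of chloro on an aromatic carbon. For the measured compounds named here, no measured pair isolates this change. Because compound 1 sits at 10000 nM and compound 2 at 5500 nM with fluoro on the sulfanyl phenyl ring, nothing points to a step beyond the scatter; the expected step from compound 1 to compound 3 in this assay is a 1.1-fold lower number from compound 1 to compound 3 (0.05 log units; within the scatter), essentially none. Compound 3 is estimated at 9000 nM, with a range from 3000 nM to 30000 nM.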

Compound 3, half-maximal inhibitory concentration: 11500 nM
Compound 3: middle estimate off by 1.3-fold (0.11 log units), on the low side; the measured number falls inside the stated range.
By their numbers in this assay, from the lowest: compounds 2, 1 and 3 (each within the scatter of the next, the first and the last beyond it).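

In this assay, among these compounds, fluoro in place of chloro on an aromatic carbon of the sulfanyl phenyl ring, para to a large group, gives a 1.2-fold higher number from compound 1 to compound 3 (0.06 log units; within the scatter) and is the first single-change pair. At this position, with the aryl of compound 1 held constant, the read-out does not separate 4-chlorophenyl from 4-fluorophenyl, whereas compound 1 and compound 2 differ in more than one place and could not isolate this change. No measured property of these groups accompanies the step, so the data offer no explanation for it.

As far as these compounds go, whether an amine, a carboxylic acid or a methoxy group at this position would give a step beyond the scatter remains open. Also open, from the compounds shown here alone, is whether the same halogen swap gives a similar step with the aryl of compound 2 on the shared core.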